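The source may report more compounds than this note shows. Statements on the series, on what has been measured and on what is new or still open speak of the compounds shown alone.

Measured compounds in a functional assay on HEK293 cells for activation of melanin-concentrating hormone receptor 1 (Homo sapiens), read by inositol phosphate accumulation; a higher number here means that more compound is needed for the effect, a lower number that less compound is needed:
compound 1 `CCCc1cc(N)c2cc(NC(=O)/C=C/c3ccc(F)cc3)ccc2n1` gives 200 nM;
compound 2 `CCCc1cc(N)c2cc(NC(=O)/C=C/c3ccc(C(C)C)cc3)ccc2n1` gives 520 nM;
compound 3 `CCCCc1ccc(/C=C/C(=O)Nc2ccc3nc(CCC)cc(N)c3c2)cc1` gives 740 nM.

Compound 3 has the highest number of the three. Its gap to compound 2 is within the scatter; only its gap to compound 1 stands beyond it, a 3.7-fold higher number from compound 1 to compound 3 (0.57 log units; beyond the scatter). Compound 4 `CCCc1cc(N)c2cc(NC(=O)/C=C/c3ccc(I)cc3)ccc2n1` differs from compound 3 in one place: iodo in place of butyl on an aromatic carbon. Among the compounds with values here, the steps that bear on this change are the two that exchange fluoro on the same aromatic carbon for an alkyl group, a 2.6-fold higher number from compound 1 to compound 2 (0.41 log units; beyond the scatter) and a 3.7-fold higher number from compound 1 to compound 3 (0.57 log units; beyond the scatter), while a 1.4-fold higher number from compound 2 to compound 3 (0.15 log units; within the scatter) shows that the two alkyl groups are not told apart. Iodo brings a single heavy atom, a halogen as in compound 1, to the position that carries butyl in compound 3. On these numbers the change is expected to lower the number in this assay, with a step of a 2.5-fold lower number from compound 3 to compound 4 (0.39 log units; beyond the scatter), the span between compound 1 and compound 3 bounding the expectation. Compound 4 is therefore expected to give about 300 nM, within 120 nM to 750 nM.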

Compound 4, half-maximal effective concentration: 280 nM
Estimate against measurement, compound 4: 1.1-fold (0.03 log units) above; measured number inside the range.
By their numbers in this assay, from the lowest: compounds 1, 4, 2 and 3 (each within the scatter of the next, the first and the last beyond it).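

In this assay, iodo at this position, para to a large group, separates from butyl, with a 2.6-fold lower number from compound 3 to compound 4 (0.42 log units; beyond the scatter), so the position does not respond to the exchange of butyl alone as it did among the alkyl groups. Iodo is not told apart from fluoro, with a 1.4-fold higher number from compound 1 to compound 4 (0.15 log units; within the scatter), nor from isopropyl, with a 1.9-fold lower number from compound 2 to compound 4 (0.27 log units; within the scatter), although fluoro and isopropyl are told apart from each other. A halogen at this position therefore does not guarantee a number on the fluoro side of the series, and the split between halogens and alkyl groups is not clean: compound 4 cannot be assigned to either side.

On these data alone, how an amine, a carboxylic acid or a longer chain at this position would read remains open. Nothing given here accounts for the size of these steps.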